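Hydroxy Gives Way to Chloro on the Fused Core

A few compounds are considered here, and "the series" means these few. Any claim that something is new, unique, unknown or untested is made for them only; others in the source may bear on it.

Compound 1 `CCc1c(F)c(N)c2c(=O)cc(-c3ccc(N)c(F)c3)oc2c1F`: 130 nM
Compound 2 `CCCCCCc1c(F)c(N)c2c(=O)cc(-c3ccc(N)c(F)c3)oc2c1F`: > 10000 nM
Compound 3 `Nc1ccc(-c2cc(=O)c3c(N)c(F)c(O)c(F)c3o2)cc1F`: > 10000 nM

In a functional assay on MCF7 cells (Homo sapiens) for cytotoxicity, read by neutral red uptake, with a stated time of 3 days (a higher number here means a weaker inhibitor, a lower number a stronger inhibitor), compound 1 gives 130 nM. For compound 2 the value of > 10000 nM is a limit of the assay, not a number. For compound 3 the value of > 10000 nM is likewise a limit, so compound 3 stands at the limit of > 10000 nM in this assay, at which 2 of the 3 values shown sit. Compound 4 `Nc1ccc(-c2cc(=O)c3c(N)c(F)c(Cl)c(F)c3o2)cc1F` differs from compound 3 by chloro in place of hydroxy on an aromatic carbon. Within the data shown here, two measured steps bear on this change: an at least 76-fold higher number from compound 1 to compound 3 (1.88 log units; beyond the scatter) and an at least 76-fold higher number from compound 1 to compound 2 (1.88 log units; beyond the scatter). The step that the two limits leave unreadable from compound 2 to compound 3 cannot be read. Because an at least 76-fold higher number from compound 1 to compound 3 (1.88 log units; beyond the scatter) came with hydroxy and an at least 76-fold higher number from compound 1 to compound 2 (1.88 log units; beyond the scatter) with hexyl, while chloro is neither, compound 4 is expected to return to a readable number, a step estimated at an at least 6.6-fold lower number from compound 3 to compound 4 (0.82 log units; beyond the scatter). Compound 4 is therefore estimated at 1500 nM, with a range from 150 nM to 15000 nM.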

Compound 4, half-maximal inhibitory concentration: 210 nM
The estimate for compound 4 lay 7.1-fold (0.85 log units) above the measured number; the measured number falls inside the stated range.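

In this assay, this position, ortho to two fluoro groups, can carry a group other than ethyl and still give a readable number: chloro gives an at least 47-fold lower number from compound 3 to compound 4 (1.67 log units; beyond the scatter) and an at least 47-fold lower number from compound 2 to compound 4 (1.67 log units; beyond the scatter). Set against ethyl, chloro gives a 1.6-fold higher number from compound 1 to compound 4 (0.21 log units; within the scatter), so the two groups cannot be told apart here. Only hydroxy and hexyl stand at a limit of the assay rather than at a number: the limit of > 10000 nM in this assay, at which 2 of the 4 values shown sit.

Going by these compounds, whether a readable number also holds for other groups here, such as an amine, a methoxy or a propyl chain, stays open. Four compounds give no rule for which groups are tolerated at this position.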